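The compounds below may be only part of what the source reports. "The series", "measured", "known", "first", "only" and "open" are said of these compounds alone.

Measured in an ADME assay on microsomes from liver (Mus musculus) for metabolic stability, read by LC-MS, using NADPH, with stated times of 15 min and 60 min, tested at 4.6 uM; a lower number here means that the compound disappears faster, a higher number that the compound lasts longer:

- compound 1 `CN1CCC(c2ccc3c(c2)oc(=O)n3C(=O)NCCCCc2ccccc2)CC1=O` gives 0.583 h
- compound 2 `CC(C)CN1CCC(c2ccc3c(c2)oc(=O)n3C(=O)NCCCCc2ccccc2)CC1` gives 1 h
- compound 3 `CN1CCC(c2ccc3c(c2)oc(=O)n3C(=O)NCCCCc2ccccc2)CC1` gives 0.667 h

These three numbers lie close together, and compound 3 has no distinct rank among them. This shows in a 1.1-fold higher number from compound 1 to compound 3 (0.06 log units; within the scatter) and in a 1.5-fold lower number from compound 2 to compound 3 (0.18 log units; within the scatter). Neither step rises above the ordinary noise of repeated measurements.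

The next compound is compound 4 `CCN1CCC(c2ccc3c(c2)oc(=O)n3C(=O)NCCCCc2ccccc2)CC1`. It carries methyl in place of hydrogen on a saturated chain carbon bound to an amine nitrogen in a ring, so 1-methylpiperidin-4-yl becomes 1-ethylpiperidin-4-yl. The counted change is methyl in place of hydrogen on a saturated chain carbon bound to an amine nitrogen in a ring.

The most relevant evidence is a 1.5-fold lower number from compound 2 to compound 3 (0.18 log units; within the scatter), which involves the same kind of carbon and links 1-isobutylpiperidin-4-yl to 1-methylpiperidin-4-yl. The change to compound 4 is smaller than that one. a 1.7-fold higher number from compound 1 to compound 2 (0.23 log units; within the scatter) and a 1.1-fold higher number from compound 1 to compound 3 (0.06 log units; within the scatter) bear on it less directly, since both start from 1-methyl-2-oxopiperidin-4-yl. All of this rests on very few compounds, and none of these steps exceeds the scatter, so no real shift is expected in this assay.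

The expected result is a 1.1-fold higher number from compound 3 to compound 4 (0.05 log units; within the scatter).

For compound 4 the estimated half-life is 0.75 h, with an expected range from 0.45 h to 1.2 h.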

Compound 4, half-life: 1 h
For compound 4 the middle estimate is 1.3-fold (0.12 log units) below the measured one; low and high end bracket the measured number.
By their numbers in this assay, from the lowest: compounds 1, 3, 2 and 4 (each within the scatter of the next).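

In this assay, among the compounds shown here, this is the first direct reading of methyl in place of hydrogen on a saturated chain carbon bound to an amine nitrogen in a ring: the step shows a 1.5-fold higher number from compound 3 to compound 4 (0.18 log units; within the scatter) and so stays within the noise of the measurement. Methyl in place of isopropyl on the same carbon shows no change at the digits printed from compound 2 to compound 4 (within the scatter) and also gives no separation, and replacing 1-methyl-2-oxopiperidin-4-yl with 1-ethylpiperidin-4-yl shows a 1.7-fold higher number from compound 1 to compound 4 (0.23 log units; within the scatter), so across these four compounds neither the size of this small chain nor the swap of the ring group gives a readable difference in half-life. No measurement here offers any explanation for these small steps.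

The compounds shown leave open whether a group of a different kind on this carbon, such as a phenyl ring, a hydroxyl or a carboxylic acid, would move the half-life beyond the scatter. They also leave open what a cyclopropyl group or a longer chain, such as butyl or hexyl, would do at this place.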